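One Added Chloro on Compound 2

The compounds below may be only part of what the source reports. "The series", "measured", "known", "first", "only" and "open" are said of these compounds alone.

Of the compounds shown here, three sharing a core have been measured in a functional assay on OVCAR-4 cells (Homo sapiens) for inhibition, read by sulforhodamine B assay, with a stated time of 48 h; a lower number here means a stronger inhibitor of growth, a higher number a weaker inhibitor of growth. Compound 1 (`O=C(Nc1cccc(-n2cc(-c3ccncc3)c(-c3ccc(Cl)c(O)c3)n2)c1)Nc1cccc(C(F)(F)F)c1`) gives 3180 nM, compound 2 (`COc1cc(-c2nn(-c3cccc(NC(=O)c4cccc(C(F)(F)F)c4)c3)cc2-c2ccncc2)ccc1Cl`) gives 2280 nM, and compound 3 (`COc1cc(-c2nn(-c3cccc(NC(=O)Nc4ccc(Cl)c(Cl)c4)c3)cc2-c2ccncc2)ccc1Cl`) gives 1290 nM. Compound 2 lies within the usual scatter of both compound 1 and compound 3, so it offers a fair starting point but no clear ranking.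

Compound 4 (`COc1cc(-c2nn(-c3cccc(NC(=O)c4ccc(Cl)c(C(F)(F)F)c4)c3)cc2-c2ccncc2)ccc1Cl`) has not been measured yet. It turns the 3-(trifluoromethyl)phenyl of compound 2 into 4-chloro-3-(trifluoromethyl)phenyl: chloro in place of hydrogen on an aromatic carbon. This is chloro in place of hydrogen on an aromatic carbon, ortho to a trifluoromethyl group and para to a large group.

Within the data shown here, only one measured step bears on this change, namely a 1.8-fold lower number from compound 2 to compound 3 (0.25 log units; within the scatter). That step is an imperfect guide, since it places (3,4-dichlorophenyl)amino in place of 3-(trifluoromethyl)phenyl on a carbonyl carbon, which alters more than one chloro. Among the measured compounds shown here, no measured pair isolates the added chloro alone. The evidence therefore supports only a small expected move toward a lower number, and nothing beyond the scatter.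

The expected change is a 1.3-fold lower number from compound 2 to compound 4 (0.10 log units; within the scatter). For compound 4 the estimated value in this assay is 1800 nM, with an expected range from 850 nM to 3700 nM.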

Compound 4, concentration for 50% growth inhibition: 8040 nM
The estimate for compound 4 lay 4.5-fold (0.65 log units) below the measured number, outside the stated range (above it).
By their numbers in this assay, from the lowest: compounds 3, 2 and 1 (each within the scatter of the next, the first and the last beyond it); then compound 4.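

In this assay, among these compounds, a single chloro on the 3-(trifluoromethyl)phenyl group gives a 3.5-fold higher number from compound 2 to compound 4 (0.55 log units; beyond the scatter) and so clearly weakens growth inhibition, whereas the one earlier step, a 1.8-fold lower number from compound 2 to compound 3 (0.25 log units; within the scatter), stayed within the scatter and could not show what a chloro alone does here. The gap is wider still in a 6.2-fold higher number from compound 3 to compound 4 (0.79 log units; beyond the scatter) even though compound 3 also carries chloro in its (3,4-dichlorophenyl)amino group, so among these compounds the presence of a chloro does not by itself set the number. Nothing measured here explains why this added chloro has this effect.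

The compounds shown leave open whether this loss belongs to chloro itself or would also appear with a fluoro, a methyl, a methoxy or an amine on the same aromatic carbon. They also leave open whether the same chloro would move the number as far on the other side of the carbonyl arrangement found in compound 3, where an amino group joins the aromatic ring to the carbonyl carbon.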